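Replacing methylsulfonyl with cyano: what to expect

A few compounds are considered here, and "the series" means these few. Any claim that something is new, unique, unknown or untested is made for them only; others in the source may bear on it.

Measured in a physicochemical assay for solubility, using the shake flask method, in simulated intestinal fluid, measured as kinetic solubility, with a stated time of 2 h, at 25 degrees C, at pH 6.5; on this read-out lower numbers stand for lower solubility and higher numbers for higher solubility
Compound 1 `Cc1noc(-c2nc(C)c3c(c2N)C(=O)N(CC2CCOCC2)C3=O)n1` gives 5700 nM
Compound 2 `Cc1noc(-c2nc(C)c3c(c2N)C(=O)N(Cc2ccc(OC(F)F)cc2)C3=O)n1` gives < 5000 nM (a limit)
Compound 3 `Cc1noc(-c2nc(C)c3c(c2N)C(=O)N(Cc2ccc(S(C)(=O)=O)cc2)C3=O)n1` gives < 5000 nM (a limit)

Compound 3 has no exact number and is known only as a limit (< 5000 nM). Compound 2 shares that limit (the limit of < 5000 nM in this assay, at which 2 of the 3 values shown sit).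

Compound 4 (`Cc1noc(-c2nc(C)c3c(c2N)C(=O)N(Cc2ccc(C#N)cc2)C3=O)n1`) differs from compound 3 in one group: cyano in place of methylsulfonyl on an aromatic carbon.

The closest measured change is also a swap of groups on an aromatic carbon, but it gives no size (a step that the two limits leave unreadable from compound 2 to compound 3). The two changes starting from compound 1 offer only floors, and both floors lie within the scatter (an at least 1.1-fold lower number from compound 1 to compound 2 (0.05 log units; that floor lies within the scatter); an at least 1.1-fold lower number from compound 1 to compound 3 (0.05 log units; that floor lies within the scatter)). Neither tells how methylsulfonyl and cyano compare, so no step beyond the scatter is expected in this assay, in either direction. Among the compounds with values here, the only exact number comes from compound 1 (5700 nM), and it anchors the top of the expected range.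

The estimated change is small, and this expected step stays within the scatter (a step that the limit leaves unreadable from compound 3 to compound 4). Compound 4 may well be reported as a limit too. For compound 4 the estimated value is 3500 nM, with an expected range from 1000 nM to 7000 nM.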

Compound 4, solubility: < 5000 nM
Compound 4: no number, only a limit; the forecaster's own chance of this, stated with the estimate: 75%; the middle value does not contradict the limit.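

In this assay compound 4 gives < 5000 nM as its result, which is a limit and not a number. Within the data shown here, the only step that can be read is an at least 1.1-fold lower number from compound 1 to compound 4 (0.05 log units; that floor lies within the scatter) and, being a floor, it shows no step beyond the scatter; the steps among compound 2, compound 3 and compound 4 cannot be read. What is new is that a third group on this aromatic carbon, cyano, which has fewer heavy atoms than methylsulfonyl, also yields a limit and not an exact number, and that limit is now the most common result in the set: the limit of < 5000 nM in this assay, at which 3 of the 4 values shown sit.

From the compounds shown here alone, how cyano, methylsulfonyl and difluoromethoxy compare with one another stays open, and so does whether any of compound 2, compound 3 and compound 4 truly lies beyond the scatter from compound 1. Also open, going by these compounds, is whether a different group at this place, such as an amine or a carboxylic acid, would give an exact number in this assay and so make a step at this position readable.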